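This account rests on a few compounds, and the source may have more. Where it says the series, first, only, none or still open, it means among the compounds named here.

Within the data shown here, compound 2 `CC(C)C[C@H](NC(=S)NCc1ccccc1)c1nc2ccccc2[nH]1` is one of two compounds measured in a functional assay on A549 cells (Homo sapiens) for cytotoxicity, read by MTT assay; on this read-out higher numbers stand for weaker inhibition and lower numbers for stronger inhibition; in this assay compound 2 gives 75700 nM. The other, compound 1 `CC(C)[C@H](NC(=S)NCc1ccccc1)c1nc2ccccc2[nH]1`, gives 56100 nM in this assay, and a 1.3-fold higher number from compound 1 to compound 2 (0.13 log units; within the scatter). Compound 2 thus stands at the higher of the two numbers, but the gap to compound 1 is within the scatter, so no order between the two can be read from it. Compound 3 `CC(C)C[C@@H](NC(=S)NCc1ccccc1)c1nc2ccccc2[nH]1` has not yet been measured. (the two compounds have the same atoms and bonds and differ only in configuration as drawn: 1 of 1 stereo elements differ; a stereocentre at a saturated chain carbon is drawn S in compound 2 and R in compound 3). Among the measured compounds shown here, no measured step changes a stereocentre: the single step available, a 1.3-fold higher number from compound 1 to compound 2 (0.13 log units; within the scatter), exchanges one chain group for another and lies within the scatter, so it gives no guide to what a change of configuration does here. With nothing to point either way, the step expected in this assay is a 1.0-fold lower number from compound 2 to compound 3 (0.00 log units; within the scatter), that is, none beyond the scatter. Compound 3 is therefore expected to give about 75000 nM, with a likely range from 30000 nM to 200000 nM.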

Compound 3, half-maximal inhibitory concentration: 22400 nM
Beside the measured number, compound 3's estimate is 3.3-fold (0.52 log units) above it, and the stated range ends above it.
By their numbers in this assay, from the lowest: compound 3; then compounds 1 and 2 (each within the scatter of the next).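

In this assay, turning the stereocentre at the saturated chain carbon from S to R gives a 3.4-fold lower number from compound 2 to compound 3 (0.53 log units; beyond the scatter), so this position responds to its spatial arrangement, with the R form giving the stronger inhibition. The earlier step, which exchanged isopropyl for isobutyl, stayed within the scatter and could not show this. The step can be assigned to the stereocentre alone, because nothing else separates the pair: the fact that compounds 2 and 3 differ only in the configuration as drawn

From the compounds shown here alone, the two configurations are compared here only with the isobutyl chain, so it remains open whether the R form would also give the lower number with isopropyl, or with a longer chain or an amine at this carbon. A single cell assay also leaves open whether the same preference would appear on other cells.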